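The compounds below may be only part of what the source reports. "The series", "measured", "known", "first", "only" and "open" are said of these compounds alone.

Working notes on the series. Compound 1 `Clc1ccccc1COc1ccccc1/C=C/C(/C=C/c1ccccn1)=N/Oc1ncnc2ccccc12` gives, in a functional assay on SMMC-7721 cells (Homo sapiens) for inhibition, read by MTT assay, with a stated time of 72 h, tested at 1 uM (a lower number here means a weaker effect, a higher number a stronger effect of the compound at the concentration tested), compound 1 95.7%. Compound 2 `Cc1cccc2ncnc(O/N=C(\C=C\c3ccccn3)/C=C/c3ccccc3OCc3ccccc3Cl)c12` carries the change (methyl in place of hydrogen on an aromatic carbon); in this assay compound 2 gives 86.8%, a step of a number 8.9 percentage points lower from compound 1 to compound 2 (within the scatter). Compound 3 `Clc1ccccc1COc1ccc(/C=C/C(/C=C/c2ccccn2)=N/Oc2ncnc3ccccc23)cc1` shares its atoms with compound 1 but joined differently; the difference between the two cores is not broken down here. In this assay compound 3 gives 10.1%, the lowest of the three numbers and beyond the scatter from both compound 1 and compound 2. Compound 4 `Cc1cccc2ncnc(O/N=C(/C=C/c3ccc(OCc4ccccc4Cl)cc3)\C=C\c3ccccn3)c12` differs from compound 3 by methyl in place of hydrogen on an aromatic carbon, the same change as from compound 1 to compound 2, at the same place. Because that earlier step was a number 8.9 percentage points lower from compound 1 to compound 2 (within the scatter), a step of similar size, a number 2.1 percentage points lower from compound 3 to compound 4 (within the scatter), is expected here, leaving compound 4 near compound 3. Compound 4 is estimated at 8%, between 0% and 28%.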

Compound 4, a percentage reported as inhibition, at one concentration (the size of the read-out at that concentration, not a potency): 77%
For compound 4 the middle estimate is 69 percentage points below the measured one; measured number outside the range, above it.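

The change from quinazolin-4-yl to 5-methylquinazolin-4-yl does not carry over from one core to the other in this assay: the same change on two cores in this assay, a number 8.9 percentage points lower (within the scatter) from compound 1 to compound 2 and a number 66.9 percentage points higher (beyond the scatter) from compound 3 to compound 4, 75.8 percentage points apart, beyond the scatter of two such steps

On the core of compound 3 the change gives a number 66.9 percentage points higher from compound 3 to compound 4 (beyond the scatter), so a step read on one of these cores cannot be transferred to the other. These two pairs do not show why the steps differ, nor how the change behaves on any further core.

Going by these compounds, it remains open whether the gap between cores is particular to methyl or also appears with ethyl, methoxy, chlorine or an amine at the same place. On these data alone, it is equally open whether the second core responds to such groups elsewhere on the quinazoline.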